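A few compounds are considered here, and "the series" means these few. Any claim that something is new, unique, unknown or untested is made for them only; others in the source may bear on it.

Compound 1 `CCC(C)COc1cccc2ccc(N)nc12` is the strongest of the numbers shown: in an assay on cells with melanin-concentrating hormone receptor 1 (Homo sapiens) as the target, read by radioligand binding (a lower number here means a stronger inhibitor, a higher number a weaker inhibitor), compound 1 gives 36 nM. Compound 2 `CC1CC1COc1cccc2ccc(N)nc12` gives 1640 nM in this assay, and the change a 46-fold higher number from compound 1 to compound 2 (1.66 log units; beyond the scatter) shows how sharply this position responds to a change of group. Compound 3 `CC(CC(C)(C)C)Oc1cccc2ccc(N(C)C)nc12` gives only a limit, > 2000 nM, in this assay. Compound 4 `CSCCOc1cccc2ccc(N)nc12` is compound 1 with one change: (methylsulfanyl)methyl in place of sec-butyl on a saturated chain carbon bound to an oxygen on an aromatic ring. Among the compounds with values here, the only measured step that bears on this place is the one from compound 1 to compound 2, which was large, so a weakening well beyond the scatter is expected, though not as deep. For compound 4 the expected step is an 11-fold higher number from compound 1 to compound 4 (1.05 log units; beyond the scatter), giving an estimate of 400 nM with a range from 80 nM to 2000 nM.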

Compound 4, half-maximal inhibitory concentration: > 2000 nM
Compound 4 ended at the assay's limit; the forecaster's own chance of this, stated with the estimate: 15%; middle value at least 5.0-fold (0.69 log units) away from the limit.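

Another replacement of sec-butyl at this place also weakens binding sharply, an at least 55-fold higher number from compound 1 to compound 4 (1.74 log units; beyond the scatter), so the loss seen with compound 2 is not a single case. Compound 4 reads only as a limit of the assay, not as a number: the limit of > 2000 nM in this assay, at which 2 of the 4 values shown sit. The comparison with the other weak compound gives an at least 1.2-fold higher number from compound 2 to compound 4 (0.08 log units; that floor lies within the scatter), so compound 2 and compound 4 cannot be put in order. Still open, from the compounds shown here alone, is how far the loss in compound 4 truly goes, and whether a longer chain such as 3-methylbutyl or a cyclohexyl group could match compound 1.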